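Testing an acetyl group on the core of compound 1

The source may hold more compounds than are shown below. What is called first, only, known or untested is meant among the compounds shown, and "the series" means these compounds.

Compound 1 `C/C(=N\O)c1ccc(NC(=O)Cn2nc(-c3ccc(Cl)cc3)nc2N)cc1`: 15.3%
Compound 2 `c1ccc(-c2nc3sc(-c4ccccc4)cn3n2)cc1`: 5%

In a functional assay on SK-MEL-2 cells (Homo sapiens) for inhibition, read by sulforhodamine B assay, with a stated time of 48 h, tested at 10 uM (on this read-out higher numbers stand for more inhibition of growth at the one concentration tested and lower numbers for less inhibition of growth), compound 1 gives 15.3%, the higher of the two numbers; compound 2 gives 5%, a gap beyond the usual scatter. Compound 3 `CC(=O)c1ccc(NC(=O)Cn2nc(-c3ccc(Cl)cc3)nc2N)cc1` keeps the core of compound 1 and differs in one place: a group of 3 heavy atoms (2 carbon, 1 oxygen; no ring) in place of a group of 4 heavy atoms (2 carbon, 1 nitrogen, 1 oxygen; no ring), on an aromatic carbon. Within the data shown here, no measured pair shows a change of this kind, so the expectation rests on the small size of the swap alone. Compound 3 is expected to give about 12%, within 0% to 28%, an estimated step of a number 3.3 percentage points lower from compound 1 to compound 3 (within the scatter) that stays within the scatter, with no clear direction.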

Compound 3, percent growth inhibition at one concentration: 4.03%
Estimate against measurement, compound 3: 8 percentage points above; the measured number falls inside the stated range.
By their numbers in this assay, from the lowest: compounds 3 and 2 (each within the scatter of the next); then compound 1.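

In this assay, putting acetyl on this aromatic carbon gives a number 11.3 percentage points lower from compound 1 to compound 3 (beyond the scatter), so even a small swap at this position can change the read-out beyond the scatter. Acetyl has 0 hydrogen-bond donors and 1 hydrogen-bond acceptor, against 1 and 2 in the group it replaces, but this single pair cannot show which difference matters. Nothing measured here explains the step. As far as these compounds go, whether an amine, a carboxylic acid or a longer chain at this position would match or exceed compound 1 remains open.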